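The compounds below may be only part of what the source reports. "The series", "measured", "known", "first", "only" and "open" are said of these compounds alone.

For the measured compounds named here, compound 2 `COc1cccc(C(=O)NN(C(=O)c2ccccc2Cl)C(C)(C)C)c1` is one of three compounds measured in an assay on cells for agonist activity at ecdysone receptor (Bombyx mori), read by a luciferase reporter, with a stated time of 24 h; a higher number here means that more compound is needed for the effect, a lower number that less compound is needed. In this assay compound 2 gives 52.5 nM, the second highest of the three numbers. Compound 1 `Cc1cc(C)cc(C(=O)N(NC(=O)c2ccccc2)C(C)(C)C)c1` gives 69.2 nM, which lies within the scatter of compound 2. Compound 3 `COc1cccc(C(=O)NN(C(=O)c2ccccc2Cl)C(C)(C)C)c1C` gives 15.5 nM, and the one-place step a 3.4-fold lower number from compound 2 to compound 3 (0.53 log units; beyond the scatter) is the only measured step among these compounds. Compound 4 `Cc1ccc(C(=O)NN(C(=O)c2ccccc2Cl)C(C)(C)C)cc1C` differs from compound 2 by 3,4-dimethylphenyl in place of 3-methoxyphenyl on a carbonyl carbon. Going by the values given here, no measured step matches this exchange of one aromatic group for another. The closest guide is a 3.4-fold lower number from compound 2 to compound 3 (0.53 log units; beyond the scatter), where a methyl entered on an aromatic carbon. On that basis a modest lowering is expected for compound 4, as the step of a 1.5-fold lower number from compound 2 to compound 4 (0.18 log units; within the scatter). Compound 4 is therefore estimated at 35 nM, within 12 nM to 100 nM.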

Compound 4, half-maximal effective concentration: 87.1 nM
Beside the measured number, compound 4's estimate is 2.5-fold (0.40 log units) below it; the measured number falls inside the stated range.
By their numbers in this assay, from the lowest: compound 3; then compounds 2, 1 and 4 (each within the scatter of the next).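

In this assay, replacing 3-methoxyphenyl with 3,4-dimethylphenyl on a carbonyl carbon gives a 1.7-fold higher number from compound 2 to compound 4 (0.22 log units; within the scatter). At this position, then, the loss of the methoxy oxygen and its hydrogen-bond acceptor, together with the entry of two methyl groups, leaves the number within the scatter, unlike the added methyl in a 3.4-fold lower number from compound 2 to compound 3 (0.53 log units; beyond the scatter). Nothing available explains this result.

The compounds shown leave open whether an amine, a carboxylic acid or a longer chain such as ethoxy on this aromatic ring would move the number beyond the scatter.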